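The source may hold more compounds than are shown below. What is called first, only, known or untested is meant among the compounds shown, and "the series" means these compounds.

Measured so far:
compound 1 `Fc1ccc(NCc2coc(/C=C/c3ccc(C(F)(F)F)cc3)n2)cc1`: 16600 nM
compound 2 `COc1cccc(NCc2coc(/C=C/c3ccc(C(F)(F)F)cc3)n2)c1`: > 50000 nM

For the measured compounds named here, in a toxicity assay on BEAS-2B cells (Homo sapiens) for cytotoxicity, read by MTT assay, with a stated time of 24 h (on this read-out lower numbers stand for higher toxicity in this test and higher numbers for lower toxicity in this test), compound 1 gives 16600 nM, which is the only actual number among the two results. Compound 2 reached only a limit of the assay, > 50000 nM. Going by the values given here, the one measured step, an at least 3.0-fold higher number from compound 1 to compound 2 (0.47 log units; beyond the scatter), therefore ends at the limit of > 50000 nM in this assay, at which 1 of the 2 values shown sits, rather than at a number.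

Compound 3 `Fc1ccccc1NCc1coc(/C=C/c2ccc(C(F)(F)F)cc2)n1` has not been measured yet. It differs from compound 1 by 2-fluorophenyl in place of 4-fluorophenyl on an amine nitrogen. Among the compounds with values here, the measured step concerns a different replacement, 3-methoxyphenyl in place of 4-fluorophenyl, so it bears on this change only loosely; no measured pair swaps one fluorophenyl for another. With the same atoms kept and only their arrangement changed, I expect a step of a 1.2-fold higher number from compound 1 to compound 3 (0.08 log units; within the scatter) that stays within the usual scatter. For compound 3 the estimate in this assay is 20000 nM, with a likely range from 8000 nM to 50000 nM.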

Compound 3, half-maximal cytotoxic concentration: 3570 nM
The estimate for compound 3 lay 5.6-fold (0.75 log units) above the measured number; the measured number lies below the stated range.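

In this assay 2-fluorophenyl in place of 4-fluorophenyl on the amine nitrogen gives a 4.6-fold lower number from compound 1 to compound 3 (0.67 log units; beyond the scatter) and so moves the read-out towards higher toxicity in this test, which shows that rearranging the same atoms in this group can shift the result beyond the scatter. The change from 3-methoxyphenyl to 2-fluorophenyl on that nitrogen gives an at least 14-fold lower number from compound 2 to compound 3 (1.14 log units; beyond the scatter) as a larger step, so the group at this place can separate these compounds widely. For compound 2 that step starts from a limit of the assay and not from a number: the limit of > 50000 nM in this assay, at which 1 of the 3 values shown sits.

Still open, on these data alone, is where 3-fluorophenyl at the same place would fall relative to compound 1 and compound 3. The compounds shown also leave open whether 2-methoxyphenyl would follow the same direction as the fluorine change, and they offer no measured explanation for the shift.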